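Thiophen-3-yl for Thiophen-2-yl on a Shared Core

The source may report more compounds than this note shows. Statements on the series, on what has been measured and on what is new or still open speak of the compounds shown alone.

Measured so far:
- compound 1, `N=C(N)N/N=C/c1c(-c2cccs2)nc2sccn12`: 10200 nM
- compound 2, `CCOC(=O)c1nc2sc(Cl)cn2c1/C=N\NC(=N)N`: 20900 nM
- compound 3, `Cc1cn2c(/C=N/NC(=N)N)c(-c3cccs3)nc2s1`: 6460 nM

All three were tested in a functional assay on cells (Cancer cell lines, Homo sapiens) for inhibition; a lower number here means a stronger inhibitor of growth, a higher number a weaker inhibitor of growth. Compound 3 gives the lowest of the three numbers, but its gap to compound 1 is within the scatter, so the two cannot be ranked; only the gap to compound 2 goes beyond the scatter.

Compound 4, `Cc1cn2c(/C=N/NC(=N)N)c(-c3ccsc3)nc2s1`, has the same atoms as compound 3 joined differently: thiophen-3-yl in place of thiophen-2-yl on an aromatic carbon.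

Among the compounds with values here, no measured pair shows this change. Within the data shown here, the only single-point step, a 1.6-fold lower number from compound 1 to compound 3 (0.20 log units; within the scatter), concerns a methyl in place of hydrogen and says nothing about moving the attachment point of the thiophene. Among the measured compounds shown here, with no step that bears on the change, the expectation rests on compound 3 alone, and no step beyond the scatter is expected in either direction.

Compound 4 is therefore estimated at 7000 nM, with a range from 2500 nM to 20000 nM. For the measured compounds named here, the expected step is a 1.1-fold higher number from compound 3 to compound 4 (0.03 log units; within the scatter), with the range kept wide because no measured pair informs it.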

Compound 4, concentration for 50% growth inhibition: 11000 nM
Estimate against measurement, compound 4: 1.6-fold (0.20 log units) below; low and high end bracket the measured number.
By their numbers in this assay, from the lowest: compounds 3, 1, 4 and 2 (each within the scatter of the next, the first and the last beyond it).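

In this assay thiophen-3-yl in place of thiophen-2-yl gives a 1.7-fold higher number from compound 3 to compound 4 (0.23 log units; within the scatter) and so leaves the two attachment points of the thiophene unranked. Within the data shown here, this is the first direct reading at this position: on the methyl-bearing core, the aromatic carbon can carry the thiophene through either ring carbon without a step that stands clear of the scatter. No measurement shown here speaks to what lies behind this result.

The compounds shown leave open whether a ring other than thiophene, such as phenyl or pyridine, or a group such as an amine or a carboxylic acid, would give a step beyond the scatter at this place. They also leave open whether the same thiophene swap on the core of compound 1, which lacks the methyl, would give a similar step.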